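A few compounds are considered here, and "the series" means these few. Any claim that something is new, unique, unknown or untested is made for them only; others in the source may bear on it.

Of the compounds shown here, three that share one core have been measured so far in a physicochemical assay for solubility, read by nephelometry, measured as kinetic solubility, with a stated time of 30 min (a higher number here means a more soluble compound, a lower number a less soluble compound), and only one gives an exact reading. Compound 1 `CC(C)(O)CNCCCOc1ccc([C@H]2CC[C@]3(CC2)OOC2(O3)C3CC4CC(C3)CC2C4)cc1` gives > 100 ug/mL which is a limit of the assay and not a number. Compound 2 `c1cc([C@H]2CC[C@]3(CC2)OOC2(O3)C3CC4CC(C3)CC2C4)ccc1OC1CCNCC1` gives > 100 ug/mL which is also a limit. Among the compounds with values here, compound 3 `N[C@H]1CC[C@@H](Oc2ccc([C@H]3CC[C@]4(CC3)OOC3(O4)C4CC5CC(C4)CC3C5)cc2)CC1` gives 25 ug/mL as the only actual number of the three. The measured steps are an at least 4.0-fold lower number from compound 1 to compound 3 (0.60 log units; beyond the scatter) and an at least 4.0-fold lower number from compound 2 to compound 3 (0.60 log units; beyond the scatter) and both lie beyond the scatter, while a step that the two limits leave unreadable from compound 1 to compound 2 has no readable size.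

Compound 4 `CC(C)(CN)Oc1ccc([C@H]2CC[C@]3(CC2)OOC2(O3)C3CC4CC(C3)CC2C4)cc1` has not yet been measured. Its difference from compound 3 is 1-(aminomethyl)-1-methylethyl in place of 4-aminocyclohexyl on an oxygen on an aromatic ring and so 1-(aminomethyl)-1-methylethyl stands in place of 4-aminocyclohexyl on an oxygen on an aromatic ring. Compound 4 lacks 4-aminocyclohexyl and, like compound 1, has no ring in this group, so an at least 4.0-fold lower number from compound 1 to compound 3 (0.60 log units; beyond the scatter) read backwards suggests a higher number in this assay for it. The expected step is a 2.4-fold higher number from compound 3 to compound 4 (0.38 log units; beyond the scatter) and it remains only an estimate. Compound 4 is expected to give 60 ug/mL with an estimated range from 20 ug/mL to 100 ug/mL in this measurement.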

Compound 4, solubility: > 100 ug/mL
Compound 4 ended at the assay's limit (the forecaster's own chance of this, stated with the estimate: 35%); middle value at least 1.6-fold (0.22 log units) from the limit.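

In this assay, putting 1-(aminomethyl)-1-methylethyl in place of 4-aminocyclohexyl on the same oxygen gives an at least 4.0-fold higher number from compound 3 to compound 4 (0.60 log units; beyond the scatter). A short open chain carrying an amine now joins piperidin-4-yl, a ring, and the longer chain of compound 1 at the top of the readable range, so among the groups shown, 4-aminocyclohexyl alone gives a reading below the limit, and having a ring or not does not sort the four compounds. The steps among compound 1, compound 2 and compound 4 cannot be read, because each of these compounds gives only a limit of the assay and not a number: the limit of > 100 ug/mL in this assay, at which 3 of the 4 values shown sit.

From the compounds shown here alone, how these three compounds rank beyond that limit remains open. Also open, going by these compounds, is whether a carboxylic acid or a longer amine chain on this oxygen would stay at the limit or fall below it.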